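Propyl in place of fluoro: working notes

The compounds below may be only part of what the source reports. "The series", "measured", "known", "first", "only" and "open" are said of these compounds alone.

Measured in a functional assay on A549 cells (Homo sapiens) for antiproliferative activity, read by CCK-8 assay, with a stated time of 72 h; a higher number here means a weaker inhibitor, a lower number a stronger inhibitor

compound 1 `Cc1ccc(OCc2ccc(C(=O)Nc3ccccc3N)cc2)cc1` 5430 nM
compound 2 `COc1ccc(OCc2ccc(C(=O)Nc3ccccc3N)cc2)cc1` 5530 nM
compound 3 `Nc1ccccc1NC(=O)c1ccc(COc2ccc(F)cc2)cc1` 5370 nM

Compound 3 at 5370 nM stands level with the other two compounds (a 1.0-fold lower number from compound 1 to compound 3 (0.00 log units; within the scatter); a 1.0-fold lower number from compound 2 to compound 3 (0.01 log units; within the scatter)). Compound 4 `CCCc1ccc(OCc2ccc(C(=O)Nc3ccccc3N)cc2)cc1` carries propyl in place of fluoro on an aromatic carbon, para to a large group. The measured steps at this same place, together with a 1.0-fold higher number from compound 1 to compound 2 (0.01 log units; within the scatter) as the third, all lie within the scatter. None of them brings in propyl, so the evidence is indirect. The expected step is a 1.1-fold lower number from compound 3 to compound 4 (0.03 log units; within the scatter) and nothing beyond the scatter is foreseen. Compound 4 is estimated at 5000 nM (expected range 2500 nM to 8500 nM).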

Compound 4, half-maximal inhibitory concentration: 5210 nM
Estimate against measurement, compound 4: 1.0-fold (0.02 log units) below; the measured number falls inside the stated range.
By their numbers in this assay, from the lowest: compounds 4, 3, 1 and 2 (each within the scatter of the next).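

Working notes on the series: in (this assay), the aromatic carbon para to a large group now also accepts propyl, three heavy atoms in place of the single fluorine, with no step beyond the scatter (a 1.0-fold lower number from compound 3 to compound 4 (0.01 log units; within the scatter)). The same holds against methoxy (a 1.1-fold lower number from compound 2 to compound 4 (0.03 log units; within the scatter)) and when ethyl extends the methyl of compound 1 (a 1.0-fold lower number from compound 1 to compound 4 (0.02 log units; within the scatter)), so size at this place, across these four compounds, does not separate them. No measurement shown bears on why the numbers stay level.

Open, on these data alone, is whether an amine, a carboxylic acid or a longer chain at this place would move the number beyond the scatter.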